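Cytotoxicity Limits Across Three Measured Analogues and One Unmeasured

This account rests on a few compounds, and the source may have more. Where it says the series, first, only, none or still open, it means among the compounds named here.

compound 1, `CC1=C(C(=O)OCC2CCCCC2)C(c2cccc(O)c2)NC(=S)N1`: > 10000 nM
compound 2, `CCC1=C(C(=O)OCC2CCCCC2)C(c2cccc(O)c2)NC(=O)N1`: > 10000 nM
compound 3, `CCCC1=C(C(=O)OCC2CCCCC2)C(c2cccc(O)c2)NC(=O)N1`: > 10000 nM

In an ADME assay on CEMx174 cells (Homo sapiens) for cytotoxicity (a higher number here means that more compound is tolerated, a lower number that less compound is tolerated), compound 1 reaches only a limit of the assay. Compound 2 likewise gives only a limit. Compound 3 also stops at a limit, and the limit of > 10000 nM in this assay, at which 3 of the 3 values shown sit, sums this up. The difference between the cores of compound 1 and compound 2 is not broken down here.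

Compound 4, `CCC1=C(C(=O)OCC2CCCCC2)C(c2cccc(O)c2)NC(=S)N1`, differs from compound 1 by methyl in place of hydrogen on a saturated chain carbon bound to a double-bonded ring carbon. The same kind of change separates compound 2 from compound 3, (methyl in place of hydrogen on a saturated chain carbon, two bonds along the chain from a double-bonded ring carbon), but there the carbon sits two bonds along the chain from a double-bonded ring carbon, whereas in compound 4 it is bound to a double-bonded ring carbon. That step, a step that the two limits leave unreadable from compound 2 to compound 3, stays unreadable because of the limit of > 10000 nM in this assay, at which 3 of the 3 values shown sit. For the new pair the step of a number no higher from compound 1 to compound 4 (the limit leaves the size open) is expected to be equally unreadable, since compound 1 already sits at > 10000 nM. Compound 4 is therefore expected to give 10000 nM.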

Compound 4, half-maximal cytotoxic concentration: > 10000 nM
Compound 4: a limit, no number; the forecaster's own chance of this, stated with the estimate: 85%; the middle value lies on the limit itself.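

No size can be read for the step between compound 1 and compound 4, since both stop at a limit: the limit of > 10000 nM in this assay, at which 4 of the 4 values shown sit.

The compounds shown leave open where the true half-maximal cytotoxic concentration of any of them lies, and whether methyl in place of hydrogen shifts it.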